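This account rests on a few compounds, and the source may have more. Where it says the series, first, only, none or still open, it means among the compounds named here.

In a functional assay on A-375 cells (Homo sapiens) for cytotoxicity, read by MTT assay, with a stated time of 72 h (on this read-out lower numbers stand for stronger inhibition and higher numbers for weaker inhibition), compound 1 (`O=C1c2c[n+]([O-])c3ccccc3c2C(=O)c2c1c1ccccc1n2CCCCn1ccnc1`) gives 350 nM. Compound 2 (`O=C1c2c[n+]([O-])c3ccccc3c2C(=O)c2c1c1ccccc1n2Cc1cn([C@@H]2C[C@H](O)[C@@H](CO)O2)nn1`), which shares its core, gives 20 nM. That is the lower of the two numbers, and the gap between them lies beyond the usual scatter of the measurement.

Compound 3 (`CC1(C)OC[C@H](Cn2cc(Cn3c4c(c5ccccc53)C(=O)c3c[n+]([O-])c5ccccc5c3C4=O)nn2)O1`) has not yet been measured. It differs from compound 2 at one place: (2,2-dimethyl-1,3-dioxolan-4-yl)methyl in place of 4-hydroxy-5-(hydroxymethyl)oxolan-2-yl on an aromatic nitrogen. Thus (2,2-dimethyl-1,3-dioxolan-4-yl)methyl stands in place of 4-hydroxy-5-(hydroxymethyl)oxolan-2-yl on an aromatic nitrogen of the five-membered aromatic ring with 3 nitrogen. Among the compounds with values here, no measured pair isolates this change, so the data give no direct guide to its size.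

A moderate rise in the number is expected in this assay, close to the edge of the scatter rather than far past it. The expected step is a 3.0-fold higher number from compound 2 to compound 3 (0.48 log units; beyond the scatter). That would still leave the expected number lower than that of compound 1. Compound 1 gives 350 nM, the highest value seen on this core so far. For compound 3 the estimated value is 60 nM, with an expected range from 15 nM to 250 nM.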

Compound 3, half-maximal inhibitory concentration: 180 nM
Compound 3: the middle estimate sits 3.0-fold (0.48 log units) below what was measured, within the range that was stated.
By their numbers in this assay, from the lowest: compound 2; then compounds 3 and 1 (each within the scatter of the next).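

In this assay the change from 4-hydroxy-5-(hydroxymethyl)oxolan-2-yl to (2,2-dimethyl-1,3-dioxolan-4-yl)methyl gives a 9.0-fold higher number from compound 2 to compound 3 (0.95 log units; beyond the scatter) on an aromatic nitrogen of the five-membered aromatic ring with 3 nitrogen, and this is the only pair shown that isolates a change at this position. The read-out therefore responds to the group at this position, even though the two groups have the same count of 8 heavy atoms, so that count alone does not set the number here. The change also alters several features at once, going from 2 hydrogen-bond donors to 0, from 3 hydrogen-bond acceptors to 2, and from 3 defined stereocentres to 1, and no supporting measurement shows which of these differences matters.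

The compounds shown leave open whether the step would persist with a group that separates these features, such as 2,3-dihydroxypropyl, which would carry hydroxyl groups on an open chain in place of the dioxolane ring. They also leave open how an amine or a carboxylic acid at the end of a short chain on the same nitrogen would compare with compound 2 and compound 3.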